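The compounds below may be only part of what the source reports. "The series", "measured", "known", "first", "only" and "open" are said of these compounds alone.

The account begins with compound 1, `CC(C)Oc1noc2c1CNCC2`, which in a physicochemical assay for acid dissociation, gives 7.5. Two other compounds have been measured in this assay. Compound 2, `c1ccc(COc2noc3c2CNCC3)cc1`, gives 7.5, level with compound 1 at the digits shown and within the scatter of it; together these two stand at the top of the three numbers. Compound 3, `CCN1CCc2onc(OC)c2C1`, gives 7, a lower number than compound 1 and beyond the scatter. No change between measured compounds that differ in only one place is available. The next compound is compound 4, `C/C=C/COc1noc2c1CNCC2`, which differs from compound 1 in one place: but-2-en-1-yl in place of isopropyl on an oxygen on an aromatic ring. The step of no change at the digits printed from compound 1 to compound 4 (within the scatter) is expected to stay within the scatter because compound 2 with its quite different group on the same oxygen gives 7.5. Compound 4 is therefore estimated at 7.5 in this assay, in a range from 7.1 to 7.9.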

Compound 4, acid dissociation constant: 7.7
Compound 4: middle estimate off by 0.20 log units, on the low side; the measured number falls inside the stated range.
By their numbers in this assay, from the lowest: compound 3; then compounds 1, 2 and 4 (each within the scatter of the next).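

In this assay, within the data shown here, the exchange of isopropyl for but-2-en-1-yl on an oxygen on an aromatic ring gives a number 0.20 log units higher from compound 1 to compound 4 (within the scatter), the first step available between compounds that differ in only one place. It shows directly that, on the core of compound 1, this position accepts a chain with a double bond outside aromatic rings while the read-out stays within the scatter. No measured evidence bears on the origin of this result.

One step cannot show whether an amine, a carboxylic acid or a longer saturated chain on the same oxygen would also stay within the scatter. It also leaves open whether the same exchange would give a comparable step on the core of compound 3.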